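Adding 4-Methylphenyl to Compound 1: An Expected Cytotoxicity Read-Out

The source may report more compounds than this note shows. Statements on the series, on what has been measured and on what is new or still open speak of the compounds shown alone.

Measured in an ADME assay on PBMC cells (Homo sapiens) for cytotoxicity, read by MTT assay, with a stated time of 72 h, in the absence of a further agent; a lower number here means a stronger inhibitor, a higher number a weaker inhibitor:
- compound 1 `COc1ccc(Nc2ccc3ccccc3n2)cc1`: 91000 nM
- compound 2 `COc1ccc(Nc2cc(-c3ccc(C)cc3)ccn2)cc1`: 52000 nM
- compound 3 `Fc1ccc(Nc2ccc3ccccc3n2)cc1`: 90000 nM

Compound 1 stands level with the other two compounds, since the values of compound 2 and compound 3 both lie within the scatter of its own. The next compound, compound 4 `COc1ccc(Nc2nc3ccccc3cc2-c2ccc(C)cc2)cc1`, has not yet been measured. It differs from compound 1 by 4-methylphenyl in place of hydrogen on an aromatic carbon and so carries 4-methylphenyl in place of hydrogen on an aromatic carbon.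

Among the compounds with values here, the one measured step from compound 1 is a 1.0-fold lower number from compound 1 to compound 3 (0.00 log units; within the scatter) and it lies within the scatter, but it swaps fluoro for methoxy and does not touch the place that changes here. Compound 2 is closer to the point, as it also carries 4-methylphenyl, though on a different core. In this assay compound 2 gives 52000 nM and this stays within the scatter of compound 1 at 91000 nM on the same read-out. Within the data shown here, no measured step adds this group to the core of compound 1, so the expectation is weakly founded and points to no change beyond the scatter. The expected step is a 1.5-fold lower number from compound 1 to compound 4 (0.18 log units; within the scatter) in this assay and it is only an estimate. For compound 4 the estimated value is 60000 nM with 25000 nM to 110000 nM as the expected range.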

Compound 4, half-maximal inhibitory concentration: 137000 nM
Beside the measured number, compound 4's estimate is 2.3-fold (0.36 log units) below it; measured number above the stated range.
By their numbers in this assay, from the lowest: compounds 2, 3, 1 and 4 (each within the scatter of the next, the first and the last beyond it).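

In this assay the core of compound 1 now has its own measured step for this change, and it reads a 1.5-fold higher number from compound 1 to compound 4 (0.18 log units; within the scatter). Within the data shown here, until now the only sign for this group came from a compound on a different core, whereas here 4-methylphenyl sits on an aromatic carbon two atoms from the ring nitrogen and ortho to a group of 9 heavy atoms, and the read-out stays within the scatter of that of compound 1 even with these 7 added heavy atoms at this place. Nothing measured here bears on why the number stays within the scatter, and this single step supports no wider pattern for the position.

From the compounds shown here alone, what remains open is whether the same aromatic carbon would give a comparable read-out with a different group there, such as an amine, a carboxylic acid or a longer alkyl chain. Going by these compounds, it also remains open whether 4-methylphenyl on another aromatic carbon of the shared core, or this same change with fluoro in place of methoxy, would stay within the scatter too.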